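The compounds below may be only part of what the source reports. "The series", "measured", "known", "first", "only" and "open" are said of these compounds alone.

Compound 1 `COc1cc(O)c2c(O)cc(-c3ccccc3)nc2c1` carries a plain phenyl group on its core and stands highest of the two numbers recorded in a functional assay on K562 cells (Homo sapiens) for inhibition (on this read-out higher numbers stand for weaker inhibition and lower numbers for stronger inhibition), where compound 1 gives 1800 nM. Its nearest neighbour, compound 2 `COc1cc(O)c2c(O)cc(-c3cccc(F)c3)nc2c1`, gives 800 nM in this assay. For the measured compounds named here, the single measured step between them is a 2.3-fold lower number from compound 1 to compound 2 (0.35 log units; beyond the scatter), so a fluorine placed on the phenyl ring was enough to move the number beyond the usual scatter, though not by much.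

Compound 3 `COc1cc(O)c2c(O)cc(-c3ccccc3F)nc2c1` has not yet been measured. It differs from compound 1 by fluoro in place of hydrogen on an aromatic carbon. Going by the values given here, only one measured step bears on this change, the one from compound 1 to compound 2, which adds the same fluoro to the same phenyl ring at a different place and lowers the number modestly. A fluoro ortho to a large group need not behave the same way, so the expectation is a lower number than for compound 1, of similar or smaller size, with wide uncertainty. The expected step is a 1.8-fold lower number from compound 1 to compound 3 (0.26 log units; within the scatter). Compound 3 is therefore estimated to give 1000 nM, with a likely range from 400 nM to 2500 nM.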

Compound 3, half-maximal inhibitory concentration: 1500 nM
Compound 3: the middle estimate sits 1.5-fold (0.18 log units) below what was measured; the measured number falls inside the stated range.
By their numbers in this assay, from the lowest: compounds 2, 3 and 1 (each within the scatter of the next, the first and the last beyond it).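

In this assay the change from phenyl to 2-fluorophenyl gives a 1.2-fold lower number from compound 1 to compound 3 (0.08 log units; within the scatter) and so cannot be told apart from no change at all on this read-out. Moving the fluoro from 3-fluorophenyl to 2-fluorophenyl gives a 1.9-fold higher number from compound 2 to compound 3 (0.27 log units; within the scatter) and is likewise too small to separate the two compounds, which puts compound 3 within the scatter of both neighbours even though compound 1 and compound 2 stand apart, so these numbers cannot show whether the place of the fluoro on the phenyl ring matters. Nothing available offers a reason for this result.

On these data alone, whether a chloro, a methoxy or an amine in place of the fluoro, at the position ortho to a large group, would move the number beyond the scatter remains open. The compounds shown also say nothing about changes to the shared core, such as a longer chain in place of its methoxy group.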